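From Cyclopentyl Ether to Phenyl Amide on a Shared Core

A few compounds are considered here, and "the series" means these few. Any claim that something is new, unique, unknown or untested is made for them only; others in the source may bear on it.

For the measured compounds named here, compound 2 `Cc1nn(-c2ncnc3nc[nH]c23)c2c1C(OC1CCCC1)CC(=O)N2` gives 2 nM in a functional assay on HEK293 cells for agonist activity at G-protein coupled receptor 39 (Homo sapiens), read by scintillation proximity assay and inositol phosphate accumulation, with a stated time of 75 min, in the presence of a further agent that is not named here (a higher number here means that more compound is needed for the effect, a lower number that less compound is needed), and compound 1 `Cc1nn(-c2ncnc3nc[nH]c23)c2c1C(OCc1ccc(Cl)cc1Cl)CC(=O)N2` gives 4 nM; the single measured step of a 2.0-fold lower number from compound 1 to compound 2 (0.30 log units; within the scatter) shows that the two sit within the scatter of each other. Compound 3 `Cc1nn(-c2ncnc3nc[nH]c23)c2c1C(C(=O)Nc1ccccc1)CC(=O)N2` carries a different kind of change: phenylcarbamoyl in place of cyclopentyloxy on a saturated ring carbon. Going by the values given here, no measured step here exchanges an ether for an amide, so the one precedent, a swap between two ether groups, bears on it only weakly. A moderate move toward a higher number is therefore expected, a 7.5-fold higher number from compound 2 to compound 3 (0.88 log units; beyond the scatter), with wide uncertainty. The estimate for compound 3 in this assay is 15 nM, in the range 3 nM to 100 nM.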

Compound 3, half-maximal effective concentration: 10 nM
Compound 3: the middle estimate sits 1.5-fold (0.18 log units) above what was measured; the measured number falls inside the stated range.
By their numbers in this assay, from the lowest: compounds 2 and 1 (each within the scatter of the next); then compound 3.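

Unlike the earlier swap between two ether groups, this change moves the number beyond the scatter, with a 5.0-fold higher number from compound 2 to compound 3 (0.70 log units; beyond the scatter) and a 2.5-fold higher number from compound 1 to compound 3 (0.40 log units; beyond the scatter) as its two measured steps. The position therefore responds to the kind of link placed on this saturated ring carbon, yet the amide still keeps compound 3 active at a modest cost in this assay here. Nothing available explains the shift.

With one amide shown, it stays open whether the amide hydrogen or the phenyl ring accounts for the step. A cyclopentylcarbamoyl group, an amine or a carboxylic acid on this carbon would test that further.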